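The source may report more compounds than this note shows. Statements on the series, on what has been measured and on what is new or still open speak of the compounds shown alone.

In an ADME assay on cells (Hepatocyte, Rattus norvegicus) for metabolic stability (on this read-out higher numbers stand for a longer-lived compound and lower numbers for a shorter-lived compound), compound 1 (`O=C(C1CCN(c2ncccn2)CC1)N1N=CC[C@H]1c1ccccc1`) gives 0.137 h and stands second highest of the three numbers available. Compound 3 (`CC1=NN(C(=O)C(C)(C)C)[C@H](c2ccccc2)C1`) lies lower at 0.0417 h and compound 2 (`CC(C)(C)C(=O)N1CCC1c1ccccc1`) lies higher at 0.5 h with both gaps beyond the scatter. Compound 4 (`CC(=O)N1CCC(C(=O)N2N=CC[C@H]2c2ccccc2)CC1`) is unmeasured and carries acetyl in place of pyrimidin-2-yl on an amine nitrogen in a ring, counted as acetyl in place of pyrimidin-2-yl on an amine nitrogen in a ring in full. Within the data shown here, no measured pair isolates this change, so the direction remains uncertain and only a small rise is expected. The expected step of a 1.5-fold higher number from compound 1 to compound 4 (0.16 log units; within the scatter) stays within the scatter. For compound 4 the estimate is 0.2 h with an expected range from 0.08 h to 0.5 h in this assay once measured.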

Compound 4, half-life: > 3.11 h
Compound 4: no number, only a limit; the forecaster's own chance of this, stated with the estimate: 5%; middle value at least 15-fold (1.19 log units) from the limit.
By their numbers in this assay, from the lowest: compound 3; then compound 1; then compound 2. At a limit, above all of these: compound 4.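

In this assay compound 4 gives > 3.11 h, which is a limit of the assay and not a number. Acetyl in place of pyrimidin-2-yl on an amine nitrogen in a ring gives an at least 22-fold higher number from compound 1 to compound 4 (1.35 log units; beyond the scatter), so this position, on the shared core, can carry a large change in this read-out. The full size of the step cannot be read from a limit: the limit of > 3.11 h in this assay, at which 1 of the 4 values shown sits.

As far as these compounds go, whether the step depends on the carbonyl of the acetyl or on the loss of pyrimidin-2-yl stays open. Also open, from the compounds shown here alone, is how a methanesulfonyl group, a simple alkyl chain or a carboxylic acid on this nitrogen would behave.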